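A Third Aziridine in Place of the Seven-Atom Chain

The source may hold more compounds than are shown below. What is called first, only, known or untested is meant among the compounds shown, and "the series" means these compounds.

compound 1, `CCCC1=C(N2CC2)C(=O)C(CCC)=C(N2CC2)C1=O`: 4.32
compound 2, `CC1=C(N2CC2)C(=O)C(C(C)COC(N)=O)=C(N2CC2)C1=O`: 5.93
compound 3, `CC(C)C1=C(N2CC2)C(=O)C(C(C)C)=C(N2CC2)C1=O`: 4.36

In a functional assay on L1210 cells (Mus musculus), with a stated time of 1 days (a higher number here means a more potent compound, by a factor of ten per unit of this negative logarithm, a lower number a less potent compound), compound 2 gives 5.93, the highest of the three numbers. Compound 3 stands nearest with 4.36, lower by more than the scatter. Compound 1 stands furthest with 4.32, also lower by more than the scatter. Compound 4, `CC1=C(N2CC2)C(=O)C(N2CC2)=C(N2CC2)C1=O`, awaits measurement. It differs from compound 2 by a group of 3 heavy atoms (2 carbon, 1 nitrogen; one three-membered non-aromatic ring with 1 hetero atom) in place of a group of 7 heavy atoms (4 carbon, 1 nitrogen, 2 oxygen; no ring), on a double-bonded ring carbon. For the measured compounds named here, no pair of measured compounds shows this change on its own, and compounds 1 and 3 differ from compound 2 in more than one place, so no step can be read from them. For compound 4 an upward step of moderate size is expected, a number 0.47 log units higher from compound 2 to compound 4 (beyond the scatter). Compound 4 is estimated at 6.4, within a range from 5.4 to 7.4.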

Compound 4, logarithm of the reciprocal of the active concentration, log(1/C): 6.54
For compound 4 the middle estimate is 0.14 log units below the measured one, within the range that was stated.
By their numbers in this assay, from the lowest: compounds 1 and 3 (each within the scatter of the next); then compound 2; then compound 4.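

Swapping the group of 7 heavy atoms on this double-bonded ring carbon for an aziridin-1-yl group gives, in this assay, a number 0.61 log units higher from compound 2 to compound 4 (beyond the scatter), the first step read at this position. The chain, with its hydrogen-bond donor, is therefore not required for a high number here, and a third aziridin-1-yl group serves better in this pair. Nothing available explains this gain.

On these data alone, whether the gain needs the aziridine ring at all stays open. A dimethylamino group, a morpholine or a longer chain on this carbon could settle that.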